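The compounds below may be only part of what the source reports. "The series", "measured", "known", "first", "only" and "open" are said of these compounds alone.

Among the compounds with values here, compound 3 (`COc1ccc(C(=O)O[C@H]2CC[C@]3(C)[C@H](CC[C@@](C)(O)[C@H]3CC[C@@H]3C(C)=CC[C@H]4[C@H](CC[C@]4(C)O)C3(C)C)OC2(C)C)cc1`) is one of three compounds measured in a functional assay on MDA-MB-231 cells (Homo sapiens) for antiproliferative activity, read by MTT assay, with a stated time of 72 h (a lower number here means a stronger inhibitor, a higher number a weaker inhibitor), where it gives 30600 nM. Among the three numbers it stands second highest: compound 1 (`CC1=CC[C@H]2[C@H](CC[C@]2(C)O)C(C)(C)[C@@H]1CC[C@H]1[C@]2(C)CC[C@H](OC(=O)CCC(=O)O)C(C)(C)O[C@H]2CC[C@@]1(C)O`) gives 27900 nM, and compound 2 (`CC1=CC[C@H]2[C@H](CC[C@]2(C)O)C(C)(C)[C@@H]1CC[C@H]1[C@]2(C)CC[C@H](OC(=O)NS(=O)(=O)c3ccc(C)cc3)C(C)(C)O[C@H]2CC[C@@]1(C)O`) gives 47100 nM. All three share the same core and differ only in the group attached to the carbonyl carbon of an ester. Those exchanges barely moved the read-out: a 1.1-fold higher number from compound 1 to compound 3 (0.04 log units; within the scatter), a 1.5-fold lower number from compound 2 to compound 3 (0.19 log units; within the scatter) and a 1.7-fold higher number from compound 1 to compound 2 (0.23 log units; within the scatter) all lie within the scatter of this assay.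

Compound 4 (`CC1=CC[C@H]2[C@H](CC[C@]2(C)O)C(C)(C)[C@@H]1CC[C@H]1[C@]2(C)CC[C@H](OC(=O)c3ccco3)C(C)(C)O[C@H]2CC[C@@]1(C)O`) changes the same position once more: furan-2-yl in place of 4-methoxyphenyl on a carbonyl carbon. Within the data shown here, no measured step involves a five-membered aromatic ring, so the only guide is that three quite different groups at this carbonyl carbon gave numbers within the scatter of one another. On that basis the step in this assay is expected to stay within the scatter, with no clear direction. That amounts to an expected 1.0-fold higher number from compound 3 to compound 4 (0.02 log units; within the scatter). Compound 4 is therefore estimated to give about 32000 nM, with a likely range from 13000 nM to 80000 nM.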

Compound 4, half-maximal inhibitory concentration: 14000 nM
Beside the measured number, compound 4's estimate is 2.3-fold (0.36 log units) above it; low and high end bracket the measured number.
By their numbers in this assay, from the lowest: compounds 4, 1, 3 and 2 (each within the scatter of the next, the first and the last beyond it).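

Within the data shown here, until now, every exchange at this carbonyl carbon stayed within the scatter in this assay; furan-2-yl is the first group to give steps beyond it, with a 2.2-fold lower number from compound 3 to compound 4 (0.34 log units; beyond the scatter) and a 3.4-fold lower number from compound 2 to compound 4 (0.53 log units; beyond the scatter). Against the 2-carboxyethyl group the exchange does not clear the scatter, at a 2.0-fold lower number from compound 1 to compound 4 (0.30 log units; within the scatter), so the position has now shown a response, but a modest one that holds against only two of the three earlier groups. Nothing given here explains why these groups differ in this way.

From the compounds shown here alone, it stays open whether the change follows the five-membered ring itself or its oxygen, which a thiophene or pyrrole ring or a plain phenyl ring on this carbonyl carbon would help to separate. Going by these compounds, whether an amine or a longer carbon chain here would move the number further also remains open.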